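The source may hold more compounds than are shown below. What is called first, only, known or untested is meant among the compounds shown, and "the series" means these compounds.

Going by the values given here, compound 2 `CC(C)(C)OC(=O)N1C[C@@H](n2cc(-c3ccc4c(N)n[nH]c4c3)nn2)C[C@H]1C(=O)Nc1ccc(Cl)cc1Cl` gives 12200 nM in a functional assay on K562 cells (Homo sapiens) for inhibition, read by MTT assay, with a stated time of 48 h (a lower number here means a stronger inhibitor, a higher number a weaker inhibitor), the higher of the two numbers measured so far. Among the compounds with values here, its only measured neighbour, compound 1 `CC(C)(C)OC(=O)N1C[C@@H](n2cc(-c3ccc4c(N)n[nH]c4c3)nn2)C[C@H]1C(=O)Nc1ccc(Cl)c(C(F)(F)F)c1`, gives 10500 nM in this assay, and the two values lie within the scatter of each other. Within the data shown here, the single known step, a 1.2-fold higher number from compound 1 to compound 2 (0.07 log units; within the scatter), changed only the group on the amide-type nitrogen and moved the number by less than the scatter.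

Compound 3 `CC(C)(C)OC(=O)N1C[C@@H](n2cc(-c3ccc4c(N)n[nH]c4c3)nn2)C[C@H]1C(=O)Nc1ccc(Br)cc1` has not been measured yet. It differs from compound 2 in one place: 4-bromophenyl in place of 2,4-dichlorophenyl on an amide-type nitrogen. Among the measured compounds shown here, this is again a change of the group on the amide-type nitrogen alone, so the one known step bears on it directly, and that step was within the scatter. No step beyond the scatter is therefore expected in this assay. The expected step is a 1.0-fold lower number from compound 2 to compound 3 (0.01 log units; within the scatter). Compound 3 is estimated to give about 12000 nM in this assay, with a likely range from 5000 nM to 30000 nM.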

Compound 3, half-maximal inhibitory concentration: 3710 nM
Estimate against measurement, compound 3: 3.2-fold (0.51 log units) above; measured number outside the range, below it.
By their numbers in this assay, from the lowest: compound 3; then compounds 1 and 2 (each within the scatter of the next).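

Changing the group on the amide-type nitrogen can move the number in this assay after all, since 4-bromophenyl gives a 3.3-fold lower number from compound 2 to compound 3 (0.52 log units; beyond the scatter) and a 2.8-fold lower number from compound 1 to compound 3 (0.45 log units; beyond the scatter). Both steps are modest but beyond the scatter, which makes compound 3 the strongest inhibitor of the three, although the two earlier groups had stayed within the scatter of each other. The change swaps chlorine for bromine and also leaves a single substituent on the ring where 2,4-dichlorophenyl and 4-chloro-3-(trifluoromethyl)phenyl each carry two, and nothing available gives a cause for the shift.

The compounds shown cannot separate those two differences, which a 4-chlorophenyl group on the same nitrogen would begin to do. From the compounds shown here alone, whether any halogen is needed at all remains open, and a plain phenyl group would bear on that.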